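A few compounds are considered here, and "the series" means these few. Any claim that something is new, unique, unknown or untested is made for them only; others in the source may bear on it.

Measured in a physicochemical assay for solubility, in phosphate buffer, at pH 7.4; a higher number here means a more soluble compound, a lower number a less soluble compound:

- compound 1 `CC(=O)N[C@@H]1CCC[C@H](C(=O)Nc2cc(-c3cnn4c3CC(C)(C)C4)ccn2)C1` gives 970000 nM
- compound 2 `CC(=O)N[C@@H]1CCC[C@H](C(=O)Nc2cc(-c3cnn4c3CC(C)(C)C4)c(F)cn2)C1` gives 550000 nM
- compound 3 `CC(=O)N[C@@H]1CCC[C@H](C(=O)Nc2cc(-c3cnn4c3CC(C)(C)C4)c(Cl)cn2)C1` gives 150000 nM

Compound 3 has the lowest of the three numbers in this assay and its nearest neighbour is compound 2. The next structure, compound 4 `CC(=O)N[C@@H]1CCC[C@H](C(=O)Nc2cc(-c3cnn4c3CC(C)(C)C4)c(C#N)cn2)C1`, differs from compound 3 in one place: cyano in place of chloro on an aromatic carbon with cyano in place of chloro on an aromatic carbon.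

Going by the values given here, no measured compound carries cyano, so the evidence is indirect. Among the compounds with values here, two steps bear on the change: a 6.5-fold lower number from compound 1 to compound 3 (0.81 log units; beyond the scatter) and a 3.7-fold lower number from compound 2 to compound 3 (0.56 log units; beyond the scatter) are both modest, and both end at the chloro compound. A third, a 1.8-fold lower number from compound 1 to compound 2 (0.25 log units; within the scatter), stays within the scatter. Across these three compounds, then, hydrogen and fluoro stand higher than chloro. Whether cyano would join them is not shown, but taking chloro away is expected to move the number up rather than down, and by no more than those modest steps. The expected result is a 2.1-fold higher number from compound 3 to compound 4 (0.33 log units; beyond the scatter) in this assay and this estimated step may not clear the scatter. For compound 4 the estimated value is 320000 nM (expected range 110000 nM to 800000 nM).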

Compound 4, solubility: 380000 nM
Estimate against measurement, compound 4: 1.2-fold (0.07 log units) below; the range from low to high includes it.
By their numbers in this assay, from the lowest: compound 3; then compounds 4, 2 and 1 (each within the scatter of the next, the first and the last beyond it).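

In this assay, replacing chloro with cyano on this aromatic carbon, ortho to one large group and para to another, gives a 2.5-fold higher number from compound 3 to compound 4 (0.40 log units; beyond the scatter) and so shows that a group of two heavy atoms, one of them a hydrogen-bond acceptor, need not stand as low here as chloro does. Measured against fluoro, the same position gives a 1.4-fold lower number from compound 2 to compound 4 (0.16 log units; within the scatter) and leaves compound 2 and compound 4 indistinguishable, whereas measured against hydrogen it gives a 2.6-fold lower number from compound 1 to compound 4 (0.41 log units; beyond the scatter) and sets the nitrile modestly apart from the unsubstituted compound. Among the four groups compared at this place, chloro alone stands clear of all the others at the low end, while cyano lies within the scatter of fluoro and fluoro within the scatter of hydrogen, so the series forms no clean ladder of separate steps.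

Nothing available explains why these groups differ in this way. As far as these compounds go, how an amine, a methoxy group or a carboxylic acid would behave on this same aromatic carbon remains open, as does whether these steps would hold with any part of the core of compound 1 changed.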